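Dienone series: phenyl to pyridin-3-yl on the side arm

The source may report more compounds than this note shows. Statements on the series, on what has been measured and on what is new or still open speak of the compounds shown alone.

Measured so far in a functional assay on MCF7 cells (Homo sapiens) for cytotoxicity, read by sulforhodamine B assay, with a stated time of 48 h; on this read-out lower numbers stand for stronger inhibition and higher numbers for weaker inhibition:
Compound 1, `CC1=C(/C=C/C(=O)/C=C/c2ccccc2)C(C)(C)CCC1`: 10600 nM
Compound 2, `COc1ccccc1/C=C/C(=O)/C=C/C1=C(C)CCCC1(C)C`: 13400 nM
Compound 3, `CC1=C(/C=C/C(=O)/C=C/c2ccccc2[N+](=O)[O-])C(C)(C)CCC1`: 10100 nM

Compound 1 holds the second highest of the three numbers in this assay. Its nearest neighbour is compound 3, with a 1.0-fold lower number from compound 1 to compound 3 (0.02 log units; within the scatter); the furthest is compound 2, with a 1.3-fold higher number from compound 1 to compound 2 (0.10 log units; within the scatter). The remaining pair gives a 1.3-fold lower number from compound 2 to compound 3 (0.12 log units; within the scatter). All three compounds therefore sit within the scatter of one another, and no ordering among them can be read from these numbers.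

Compound 4 is `CC1=C(/C=C/C(=O)/C=C/c2cccnc2)C(C)(C)CCC1`. Relative to compound 1 the change is pyridin-3-yl in place of phenyl on a double-bonded chain carbon bound to a double-bonded chain carbon.

The measured steps all concern a substituent placed on the aromatic ring of compound 1, and none of them moved the number beyond the scatter. None exchanges the ring itself for a ring with a hetero atom, so the bearing of those steps on compound 4 is indirect: they only show that this part of the molecule tolerated small variation without a shift in this assay. On that basis no step beyond the scatter is expected for compound 4, in either direction, and the estimate is a 1.1-fold lower number from compound 1 to compound 4 (0.03 log units; within the scatter).

Compound 4 is accordingly estimated at 10000 nM, within a range of 4000 nM to 25000 nM.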

Compound 4, half-maximal inhibitory concentration: 15500 nM
For compound 4 the middle estimate is 1.6-fold (0.19 log units) below the measured one; low and high end bracket the measured number.
By their numbers in this assay, from the lowest: compounds 3, 1, 2 and 4 (each within the scatter of the next).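

Replacing the ring itself, rather than decorating it, gives a 1.5-fold higher number from compound 1 to compound 4 (0.17 log units; within the scatter) in this assay. At this place, on a double-bonded chain carbon bound to a double-bonded chain carbon, pyridin-3-yl can therefore stand in for phenyl with no step beyond the scatter, even though the heavy-atom count stays the same while a hetero atom and a hydrogen-bond acceptor enter; the substituent steps on the phenyl ring of compound 1 could not show this. No measurement at hand explains this result or shows whether the added hetero atom plays any part in it.

Still open, on these data alone, is whether the same holds for pyridin-2-yl, pyridin-4-yl or a thiophene ring at this place, or for a pyridin-3-yl ring carrying a dimethylamino group or a carboxylic acid. As far as these compounds go, all four compounds also keep the rest of the core of compound 1 unchanged, so it remains unknown whether a longer chain between the carbonyl and the ring would move the number beyond the scatter.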